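Swapping a chlorophenyl for a trifluoromethylthiophene

The source may report more compounds than this note shows. Statements on the series, on what has been measured and on what is new or still open speak of the compounds shown alone.

Compound 1, `Cc1c(C2CC2)nc2ncc(-n3ccc(OCc4ccc(Cl)cc4)cc3=O)cn12`: > 1000 nM
Compound 2, `Cn1c(C2CC2)nc2ccc(-n3ccc(OCc4ccc(Cl)cc4)cc3=O)cc21`: 35 nM
Compound 3, `Cc1nc2ccc(-n3ccc(OCc4ccc(F)cc4)cc3=O)cc2n1C`: 77 nM

Of the compounds shown here, three have so far been measured in an assay on CHO cells for displacement of a labelled ligand from melanin-concentrating hormone receptor 1 (Homo sapiens), read by scintillation counting, with a stated time of 1 h; a higher number here means a weaker inhibitor, a lower number a stronger inhibitor. Compound 2 gives the lowest of the two numbers, and compound 3 gives a higher number, a gap beyond the usual scatter of repeat measurements. Compound 1 reaches only the limit of the assay, (the limit of > 1000 nM in this assay, at which 1 of the 3 values shown sits), so no number is known for it.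

Compound 4, `Cn1c(C2CC2)nc2ccc(-n3ccc(OCc4cc(C(F)(F)F)cs4)cc3=O)cc21`, has not yet been measured. It differs from compound 2 in one place: 4-(trifluoromethyl)thiophen-2-yl in place of 4-chlorophenyl on a saturated chain carbon bound to an oxygen on an aromatic ring. Within the data shown here, no measured pair shows this particular change, so its effect can only be estimated from what compound 2 itself gives, 35 nM. The step of a 1.4-fold higher number from compound 2 to compound 4 (0.15 log units; within the scatter) is expected to be small, perhaps leaning slightly toward a weaker number, but within or close to the scatter. For compound 4 the estimate is 50 nM, with a range from 15 nM to 200 nM.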

Compound 4, half-maximal inhibitory concentration: 34 nM
Compound 4: the middle estimate sits 1.5-fold (0.17 log units) above what was measured, within the range that was stated.
By their numbers in this assay, from the lowest: compounds 4 and 2 (each within the scatter of the next); then compound 3. At a limit, above all of these: compound 1.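

In this assay, placing 4-(trifluoromethyl)thiophen-2-yl where 4-chlorophenyl stood, on a saturated chain carbon bound to an oxygen on an aromatic ring, gives a 1.0-fold lower number from compound 2 to compound 4 (0.01 log units; within the scatter), so this read-out does not tell the two compounds apart. The earlier compounds shown here held only substituted phenyl rings at this place; now a five-membered aromatic ring with 1 hetero atom is seen there too, and it reads alike with the six-membered ring of carbon only. The two groups differ in ring size, in atoms and in heavy-atom count, yet this pair shows that those differences taken together leave the number within the scatter.

Going by these compounds, whether this place also tolerates a group of another kind, such as an amine or a carboxylic acid, remains open. Nothing measured here speaks to why the two groups read alike.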